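The compounds below may be only part of what the source reports. "The series", "measured", "known", "first", "only" and "open" are said of these compounds alone.

In a functional assay on PA-1 cells (Homo sapiens) for cytotoxicity, read by MTT assay, with a stated time of 4 h (a lower number here means a stronger inhibitor, a higher number a weaker inhibitor), compound 1 (`COC(=O)C1=CO[C@@H](O[C@@H]2O[C@H](COC(c3ccccc3)(c3ccccc3)c3ccccc3)[C@@H](O)[C@H](O)[C@H]2O)[C@@H]2[C@@H](C)[C@@H](O)C[C@H]12`) reads 0.65 ug/mL and compound 2 (`CCC(=O)OC[C@H]1O[C@@H](O[C@@H]2OC=C(C(=O)OC)[C@H]3C[C@H](OC(C)=O)[C@H](C)[C@@H]23)[C@H](OC(C)=O)[C@@H](OC(C)=O)[C@@H]1OC(C)=O`) reads 1.24 ug/mL within the scatter of each other. Compound 3 (`CCCCCCCCCCCCCC(=O)OC[C@H]1O[C@@H](O[C@@H]2OC=C(C(=O)OC)[C@H]3C[C@H](OC(C)=O)[C@H](C)[C@@H]23)[C@H](OC(C)=O)[C@@H](OC(C)=O)[C@@H]1OC(C)=O`) reads 6.5 ug/mL and so lies beyond the scatter above compound 2. Compound 4 (`C=CC(=O)OC[C@H]1O[C@@H](O[C@@H]2OC=C(C(=O)OC)[C@H]3C[C@H](OC(C)=O)[C@H](C)[C@@H]23)[C@H](OC(C)=O)[C@@H](OC(C)=O)[C@@H]1OC(C)=O`) departs from compound 2 by one change (vinyl in place of ethyl on a carbonyl carbon) with vinyl in place of ethyl on a carbonyl carbon. Among the compounds with values here, the only measured step on that chain (a 5.2-fold higher number from compound 2 to compound 3 (0.72 log units; beyond the scatter)) puts undecyl in place of hydrogen and is modest. It lengthens the chain, which the present change does not, so it sets no direction here and this assay is expected to show nothing beyond the scatter. The expected change (a 1.1-fold lower number from compound 2 to compound 4 (0.05 log units; within the scatter)) stays small. Compound 4 is estimated at 1.1 ug/mL (expected range 0.5 ug/mL to 2.6 ug/mL).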

Compound 4, half-maximal inhibitory concentration: "not active" (no number reported)
Compound 4 has no reported number here, and the estimate cannot be compared.
By their numbers in this assay, from the lowest: compounds 1 and 2 (each within the scatter of the next); then compound 3.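

Within the data shown here, compound 4 is recorded as "not active" with no number in this assay, so no step from compound 2 to compound 4 can be read. On these data alone, what vinyl in place of ethyl does to the reading stays open. No measured evidence bears on this result.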